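This account rests on a few compounds, and the source may have more. Where it says the series, first, only, none or still open, it means among the compounds named here.

Compound 2, whose structure is `CCCCCOCCCCCCCCCc1cc2cn([C@H]3C[C@H](O)[C@@H](CO)O3)c(=O)nc2o1`, is one of three close relatives of a shared core tested in a functional assay on HEL cells (Homo sapiens) for cytotoxicity; on this read-out lower numbers stand for higher toxicity in this test and higher numbers for lower toxicity in this test. In that test compound 2 gives 10000 nM. Compound 3, with structure `CC(C)CCOCCCCCCCCCc1cc2cn([C@H]3C[C@H](O)[C@@H](CO)O3)c(=O)nc2o1`, gives 10000 nM in this assay, so compound 2 stands level with compound 3 at the digits shown, and the step of no change at the digits printed from compound 2 to compound 3 (within the scatter) lies within the scatter. Compound 1 has the structure `O=c1nc2oc(CCCCCCCCCOCC3CCCC3)cc2cn1[C@H]1C[C@H](O)[C@@H](CO)O1`. For compound 1 this assay gives only a limit, >= 5000 nM, as recorded in the limit of >= 5000 nM in this assay, at which 1 of the 3 values shown sits. Because of that limit, the steps a step that the limit leaves unreadable from compound 1 to compound 2 and a step that the limit leaves unreadable from compound 1 to compound 3 cannot be read in size.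

Compound 4 is the next member, with structure `O=c1nc2oc(CCCCCCCCCOCCCCCl)cc2cn1[C@H]1C[C@H](O)[C@@H](CO)O1`. It differs from compound 2 by chloro in place of methyl on a saturated chain carbon, four bonds along the chain from an oxygen on a saturated carbon. Among the measured compounds shown here, of the measured steps, only the one from compound 2 to compound 3 is readable, and it sits within the scatter, while the two from compound 1 are unreadable; none of them tests an exchange of chloro for methyl. On this basis compound 4 is expected to stay close to compound 2, with the step of no change at the digits printed from compound 2 to compound 4 (within the scatter) not beyond the scatter. Compound 4 is therefore estimated at 10000 nM in this assay, within a range from 5000 nM to 20000 nM.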

Compound 4, minimum cytotoxic concentration: >= 200000 nM
Compound 4: no number, only a limit (the forecaster's own chance of this, stated with the estimate: 40%); at least 20-fold (1.30 log units) between middle value and limit.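

In this assay, chloro in place of methyl, four bonds along the chain from an oxygen on a saturated carbon, gives an at least 20-fold higher number from compound 2 to compound 4 (1.30 log units; beyond the scatter), and 2-chloroethyl in place of isopropyl gives an at least 20-fold higher number from compound 3 to compound 4 (1.30 log units; beyond the scatter), so on this read-out both changes point to lower toxicity in this test. The only step among the earlier compounds that could be read, isopropyl in place of propyl, was no change at the digits printed from compound 2 to compound 3 (within the scatter), so the far end of this chain had shown no sensitivity until the chloro group entered, and a change of a single heavy atom there now moves the read-out well beyond the scatter. The reading for compound 4 is a limit and not a number: the limit of >= 200000 nM in this assay, at which 1 of the 4 values shown sits.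

As far as these compounds go, the steps involving the limit for compound 1 cannot be read in size, so the cyclopentyl compound cannot be placed against compound 4, and the full size of the step to compound 4 also stays unknown. From the compounds shown here alone, whether the same shift would appear with a fluoro, a bromo or a hydroxyl group at this chain end, or with the chloro group on a shorter chain, remains open.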